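This account rests on a few compounds, and the source may have more. Where it says the series, first, only, none or still open, it means among the compounds named here.

Measured compounds:
- Compound 1, `NC(=S)Nc1cccc(OCCCCCOc2ccccc2)c1`: in an ADME assay on Ava5 cells (Homo sapiens) for cytotoxicity (a lower number here means that less compound is tolerated, a higher number that more compound is tolerated), compound 1 gives > 50000 nM, which is a limit of the assay and not a number.
- Compound 2, `CCN(CC)c1ccc(OCCCCCOc2cccc(NC(N)=S)c2)cc1`: in this assay compound 2 gives > 50000 nM, again a limit of the assay and not a number.

Among the measured compounds shown here, compound 2 therefore stands only at a limit in this assay, and the one other value shown sits at the same limit (the limit of > 50000 nM in this assay, at which 2 of the 2 values shown sit). The step from compound 1 to compound 2, diethylamino in place of hydrogen on an aromatic carbon, is a step that the two limits leave unreadable from compound 1 to compound 2; with both ends at the limit its size cannot be read.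

Compound 3 `NC(=S)Nc1cccc(OCCCCCOc2ccc(N3CCCC3)cc2)c1` differs from compound 2 by pyrrolidin-1-yl in place of diethylamino on an aromatic carbon. For the measured compounds named here, no measured step bears on this exchange with a readable size, so no shift beyond the scatter is expected in this assay, and the limit is the likeliest outcome again. Compound 3 is expected to give 60000 nM, with a range from 25000 nM to 150000 nM, a step that the limit leaves unreadable from compound 2 to compound 3 by estimate.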

Compound 3, half-maximal cytotoxic concentration: 16000 nM
Beside the measured number, compound 3's estimate is 3.8-fold (0.57 log units) above it; the measured number lies below the stated range.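

The ring matters at this position, on an aromatic carbon para to a large group: in this assay, pyrrolidin-1-yl in place of diethylamino gives an at least 3.1-fold lower number from compound 2 to compound 3 (0.49 log units; beyond the scatter), although both groups have the same heavy atoms and neither carries a hydrogen-bond donor. Set against the plain core, pyrrolidin-1-yl in place of hydrogen gives an at least 3.1-fold lower number from compound 1 to compound 3 (0.49 log units; beyond the scatter), so this is the first substituent here with a readable effect, whereas the step from compound 1 to compound 2 cannot be read. Both new steps start from a limit and not a number, so they show only the smallest possible size: the limit of > 50000 nM in this assay, at which 2 of the 3 values shown sit.

On these data alone, it remains open whether any ring on this carbon lowers the number or only pyrrolidin-1-yl does; a piperidine or morpholine ring there would test this. As far as these compounds go, the true distance of compound 3 from compound 1 and compound 2 also remains open.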